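Series notes: expected fluoro step to compound 4

The compounds below may be only part of what the source reports. "The series", "measured", "known", "first", "only" and "open" are said of these compounds alone.

In a functional assay on Bel-7402 cells (Homo sapiens) for inhibition, read by MTT assay, with a stated time of 24 h, tested at 100 ug/mL (a lower number here means less inhibition of growth, a higher number more inhibition of growth at the concentration tested), compound 1 (`O=C(CCCCC(S)CCS)Nc1ccccc1`) gives 7.67% while compound 3 (`O=C(CCCCC(S)CCS)Nc1cccc(Cl)c1`) gives 16.1% and the two numbers lie within the scatter of each other, so compound 1 holds no separate place on the numbers. Compound 2 (`O=C(CCCCC(S)CCS)Nc1ccccc1Cl`) is reported as "not active" (no number reported) with no number attached.

Compound 4 (`O=C(CCCCC(S)CCS)Nc1ccc(F)cc1`) is compound 1 with fluoro in place of hydrogen on an aromatic carbon. Among the compounds with values here, only one measured step bears on this change, chloro in place of hydrogen on an aromatic carbon (a number 8.4 percentage points higher from compound 1 to compound 3 (within the scatter)), and it stays within the scatter. Within the data shown here, no fluoro step has been measured, and compound 2 supplies no step.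

From the compounds shown here alone, no step beyond the scatter is therefore expected in this assay and the direction stays open. The estimated step is small (a number 2.3 percentage points higher from compound 1 to compound 4 (within the scatter)) and within the scatter. In this assay the estimated value for compound 4 is (10%), with an expected range (0% to 22%).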

Compound 4, percent growth inhibition at one concentration: 11.7%
The estimate for compound 4 lay 1.7 percentage points below the measured number, within the range that was stated.
By their numbers in this assay, from the lowest: compounds 1, 4 and 3 (each within the scatter of the next).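

In this assay, within the data shown here, fluoro in place of hydrogen on an aromatic carbon, para to a large group, gives a number 4 percentage points higher from compound 1 to compound 4 (within the scatter) and so provides the first measured fluoro step on the shared core. With a number 8.4 percentage points higher from compound 1 to compound 3 (within the scatter) beside it, both halogen steps with a reading from compound 1 remain within the scatter, and neither compound separates from compound 1 on the numbers. No measured information is available to account for the size of the fluoro step.

The step to compound 2 cannot be read, as no number is attached to that compound. From the compounds shown here alone, whether an amine or a carboxylic acid at the position para to a large group would give a step beyond the scatter in this assay remains open.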